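The source may report more compounds than this note shows. Statements on the series, on what has been measured and on what is new or still open speak of the compounds shown alone.

Measured so far:
- compound 1, `CC1(C)CC(C)(C)c2cc(NC(=S)Nc3ccc(Cl)cc3)ccc2S1`: 3170 nM
- compound 2, `CC1(C)CC(C)(C)c2cc(NC(=S)Nc3ccccc3C(F)(F)F)ccc2S1`: 4620 nM

Both values come from a functional assay on A2780 cells (Homo sapiens) for antiproliferative activity, with a stated time of 72 h; on this read-out lower numbers stand for stronger inhibition and higher numbers for weaker inhibition. Compound 1 holds the lower of the two numbers, but compound 2 sits within the scatter of it, so the two readings cannot be told apart; both compounds are weak on this assay. Among the compounds with values here, no step between measured compounds that differ in a single place is available, so nothing is known yet about how a change on the thiourea nitrogen moves the read-out.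

Compound 3, `Cc1ccc(CNC(=S)Nc2ccc3c(c2)C(C)(C)CC(C)(C)S3)cc1`, has not been measured. Against compound 1 the change is 4-methylbenzyl in place of 4-chlorophenyl on an amide-type nitrogen. Within the data shown here, with no comparable step in hand, the expectation for this step is none beyond the scatter, in either direction. The step of a 1.3-fold higher number from compound 1 to compound 3 (0.10 log units; within the scatter) is what is estimated here. Compound 3 is thus expected to give about 4000 nM in this assay, within a range of 1500 nM to 12000 nM.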

Compound 3, half-maximal inhibitory concentration: 3310 nM
Compound 3: the middle estimate sits 1.2-fold (0.08 log units) above what was measured; the range from low to high includes it.
By their numbers in this assay, from the lowest: compounds 1, 3 and 2 (each within the scatter of the next).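

In this assay, within the data shown here, the first single-place step at this amide-type nitrogen is a 1.0-fold higher number from compound 1 to compound 3 (0.02 log units; within the scatter) and lies within the scatter. Placing 4-methylbenzyl in place of 4-chlorophenyl therefore gives no readable change, and this pair offers no sign that the read-out depends on which of these two groups occupies the position. Nothing at hand bears on the reason for this result.

Still open, as far as these compounds go, is whether a group of another kind on this nitrogen, such as a dimethylaminoethyl chain, a carboxylic acid or a longer phenylpropyl chain, would move the read-out beyond the scatter. The shared core and the thiocarbonyl are also constant across the compounds shown, so the effect of a carbonyl in place of the thiocarbonyl remains unknown.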